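From a Methoxyphenyl Group to a Fluorophenyl Group

The source may hold more compounds than are shown below. What is called first, only, known or untested is meant among the compounds shown, and "the series" means these compounds.

Compound 2 `COc1cccc(Cn2c(CN3CCN(C(=O)C4CC4)CC3)nc3ccccc32)c1` gives 44.4% in an assay on isolated protein for inhibition of aldehyde dehydrogenase 1A1 (Homo sapiens), read by spectrophotometry, tested at 10 uM (a lower number here means less inhibition, a higher number more inhibition at the concentration tested (going by the name of the read-out)), the lowest of the three values. Compound 1 `CCC(=O)N1CCN(Cc2nc3ccccc3n2Cc2cccc(C)c2)CC1` gives 85.1% and compound 3 `Cc1cccc(Cn2c(CN3CCN(C(=O)C(C)C)CC3)nc3ccccc32)c1` gives 87.2%; both stand beyond the scatter from compound 2. Among the compounds with values here, the only measured step, a number 2.1 percentage points higher from compound 1 to compound 3 (within the scatter), alters the group on the carbonyl carbon and not the part changed on the way to compound 4 `O=C(C1CC1)N1CCN(Cc2nc3ccccc3n2Cc2ccc(F)cc2)CC1`: 4-fluorophenyl in place of 3-methoxyphenyl on a saturated chain carbon bound to an aromatic nitrogen. Within the data shown here, compounds 1 and 2 differ at the carbonyl end as well as at the group on the saturated chain carbon bound to the aromatic nitrogen, so their gap suggests this region can shift the reading strongly, but no pair tells which way 4-fluorophenyl goes. Compound 4 is therefore expected at 65% (range 35% to 90%). The expected step is a number 20.6 percentage points higher from compound 2 to compound 4 (beyond the scatter).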

Compound 4, a percentage reported as inhibition, at one concentration (the size of the read-out at that concentration, not a potency): 32.7%
The estimate for compound 4 lay 32.3 percentage points above the measured number, and the stated range ends above it.
By their numbers in this assay, from the lowest: compound 4; then compound 2; then compounds 1 and 3 (each within the scatter of the next).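

Within the data shown here, this is the first pair that differs only in the group on a saturated chain carbon bound to an aromatic nitrogen. The reading in this assay comes out a number 11.7 percentage points lower from compound 2 to compound 4 (beyond the scatter), so this position alone can shift the result, and 4-fluorophenyl in place of 3-methoxyphenyl gives less inhibition. No measurement available here explains the drop.

The compounds shown leave open whether the drop follows from losing the methoxy group or from gaining the fluorine. They also leave open how a plain phenyl, or a phenyl carrying an amine or a carboxylic acid, would read here.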